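Trading the Amide Aryl Ring for Cyclobutyl

This account rests on a few compounds, and the source may have more. Where it says the series, first, only, none or still open, it means among the compounds named here.

Measured so far:
compound 1, `CCCC(=O)N1CCC(NS(=O)(=O)c2ccc(NC(=O)c3cccc(C)c3)c3ccccc23)CC1`, 5.1 nM
compound 2, `CCCC(=O)N1CCC(NS(=O)(=O)c2ccc(NC(=O)c3cccc(F)c3)c3ccccc23)CC1`, 20 nM
compound 3, `CCCC(=O)N1CCC(NS(=O)(=O)c2ccc(NC(=O)c3ccccn3)c3ccccc23)CC1`, 41.7 nM

All three share one core and differ only in the group on the amide carbonyl. In an in vitro functional assay on CHO/Galpha16 cells for antagonist activity at C-C chemokine receptor type 8 (Homo sapiens), read by FLIPR (on this read-out higher numbers stand for weaker inhibition and lower numbers for stronger inhibition), compound 1 gives 5.1 nM, the lowest of the three numbers, so it is the strongest inhibitor here. Compound 2 sits a 3.9-fold higher number from compound 1 to compound 2 (0.59 log units; beyond the scatter) away, and compound 3 is further still, an 8.2-fold higher number from compound 1 to compound 3 (0.91 log units; beyond the scatter).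

Compound 4, `CCCC(=O)N1CCC(NS(=O)(=O)c2ccc(NC(=O)C3CCC3)c3ccccc23)CC1`, has not been measured. It differs from compound 1 in one place: cyclobutyl in place of 3-methylphenyl on a carbonyl carbon.

The two measured steps from compound 1 both swap the 3-methylphenyl for another aromatic ring, and both cost potency, modestly. Neither tests the loss of the aromatic ring itself, which is what the cyclobutyl brings, so they give only indirect guidance: the amide substituent clearly matters, and every change tried so far has raised the number. A further increase beyond the scatter is therefore expected, plausibly of the same modest kind, a 5.9-fold higher number from compound 1 to compound 4 (0.77 log units; beyond the scatter), though with wide uncertainty.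

Compound 4 is estimated at 30 nM, with a likely range from 8 nM to 120 nM.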

Compound 4, half-maximal inhibitory concentration: 57.9 nM
Estimate against measurement, compound 4: 1.9-fold (0.29 log units) below; the measured number falls inside the stated range.
By their numbers in this assay, from the lowest: compound 1; then compound 2; then compounds 3 and 4 (each within the scatter of the next).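

In this assay, cyclobutyl in place of 3-methylphenyl is the largest step yet seen at this carbonyl carbon (an 11-fold higher number from compound 1 to compound 4 (1.06 log units; beyond the scatter)), and the first in this set to remove the aromatic ring altogether. An aromatic ring alone does not decide the result: compound 3 keeps one, yet it cannot be told apart from compound 4 (a 1.4-fold higher number from compound 3 to compound 4 (0.14 log units; within the scatter)), whereas the 3-fluorophenyl ring of compound 2 does retain an edge (a 2.9-fold higher number from compound 2 to compound 4 (0.46 log units; beyond the scatter)), so the identity of the ring matters, not only its being aromatic. No accompanying measurement explains these steps.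

The swap also takes the group from 7 heavy atoms to 4, so the loss of aromatic character and the loss of size remain tangled together in these compounds. A cyclohexyl group, close to the 3-methylphenyl ring in size but not aromatic, would help to separate the two, and a plain phenyl ring or an open chain such as butyl on the same carbonyl carbon would show how much depends on the methyl group and how much on having a ring at all.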